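Cytotoxicity notes on the shared-core amide series

A few compounds are considered here, and "the series" means these few. Any claim that something is new, unique, unknown or untested is made for them only; others in the source may bear on it.

Of the compounds shown here, three have been tested in an ADME assay on MT4 cells (Homo sapiens) for cytotoxicity, read by MTT assay; a higher number here means that more compound is tolerated, a lower number that less compound is tolerated. Compound 1 `Cc1cc(C)cc(S(=O)(=O)c2c(C(=O)NCC(=O)NC(C)c3ccccc3)[nH]c3ccc(Cl)cc23)c1` gives 29400 nM in this assay. Compound 2 `COc1cccc(F)c1CNC(=O)c1[nH]c2ccc(Cl)cc2c1S(=O)(=O)c1cc(C)cc(C)c1` reaches only a limit of this assay, > 49900 nM, so no number stands for it. Compound 3 `Cc1cc(C)cc(S(=O)(=O)c2c(C(=O)Nc3cc(C#N)ccn3)[nH]c3ccc(Cl)cc23)c1` likewise returns only a limit, > 53700 nM. Compound 2 therefore stands at a limit, and its step to compound 3 is unreadable: a step that the two limits leave unreadable from compound 2 to compound 3.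

The step followed here leads from compound 2 to compound 4 `Cc1cc(C)cc(S(=O)(=O)c2c(C(=O)NCc3ccc4nc(N)[nH]c4c3)[nH]c3ccc(Cl)cc23)c1`, which is not yet measured in this assay. The change: 2-amino-1H-benzimidazol-6-yl in place of 2-fluoro-6-methoxyphenyl on a saturated chain carbon bound to an amide-type nitrogen.

The measured steps that bear on it both start from compound 1 and both end at a limit. From compound 1 to compound 2 the change gives an at least 1.6-fold higher number from compound 1 to compound 2 (0.22 log units; that floor lies within the scatter), and from compound 1 to compound 3 it gives an at least 1.8-fold higher number from compound 1 to compound 3 (0.26 log units; that floor lies within the scatter). Both floors lie within the scatter, so the series has so far shown no readable movement in this assay, and the replacement in compound 4 has no measured counterpart here.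

The expectation for compound 4 is therefore a number near the limits seen, with no step beyond the scatter. Compound 4 is expected to give about 42000 nM in this assay, within 18000 nM to 80000 nM. That estimate means an expected step of an at least 1.1-fold lower number from compound 2 to compound 4 (0.07 log units; that floor lies within the scatter), with a fair chance that the assay again reports only a limit.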

Compound 4, half-maximal cytotoxic concentration: 5890 nM
Compound 4: middle estimate off by 7.1-fold (0.85 log units), on the high side, and the stated range ends above it.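

In this assay, 2-amino-1H-benzimidazol-6-yl on a saturated chain carbon bound to an amide-type nitrogen gives the first movement beyond the scatter in this series: an at least 8.4-fold lower number from compound 2 to compound 4 (0.92 log units; beyond the scatter). Within the data shown here, the separation also holds against the other two amides, with an at least 9.1-fold lower number from compound 3 to compound 4 (0.95 log units; beyond the scatter) and with a 5.0-fold lower number from compound 1 to compound 4 (0.70 log units; beyond the scatter), the last being the only one of these steps with a measured number at both ends, as the other two start from assay limits and give only floors. Among these compounds, the group carried on this chain can therefore lower the number in this assay, which the earlier compounds could not show: their two steps gave floors within the scatter, and the step between the two limits cannot be read.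

From the compounds shown here alone, whether the lower number goes with the amine or with the rest of the entering group stays open, and a phenyl carrying only an amine, or 1H-benzimidazol-6-yl without the amine, would separate the two. Nothing in the data shown bears on what lies behind this lower number.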